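The compounds below may be only part of what the source reports. "The series", "measured", "known", "first", "only" and "open" are said of these compounds alone.

Measured compounds:
compound 1 `CCCCCNC(=O)Nc1c(OCCCn2cnc(-c3ccccc3)c2)cccc1N(C)C`, 31 nM
compound 2 `CCCCCCNc1c(OCCCn2cnc(-c3ccccc3)c2)cccc1N(C)C`, 11000 nM
compound 3 `CCCCCN(C)C(=O)Nc1c(OCCCn2cnc(-c3ccccc3)c2)cccc1N(C)C`, 550 nM

In an assay for inhibition of acyl-CoA:cholesterol acyltransferase (Oryctolagus cuniculus), using microsomes (on this read-out lower numbers stand for stronger inhibition and higher numbers for weaker inhibition), compound 1 gives 31 nM, the lowest number of the three. Compound 3 gives 550 nM and compound 2 gives 11000 nM. Both measured steps away from compound 1 alter the urea side of the shared core: an 18-fold higher number from compound 1 to compound 3 (1.25 log units; beyond the scatter) and a 350-fold higher number from compound 1 to compound 2 (2.55 log units; beyond the scatter). The heterocycle on the chain is held constant in all three measured compounds.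

Compound 4 `CCCCCNC(=O)Nc1c(OCCCn2nnc(-c3ccccc3)n2)cccc1N(C)C` differs from compound 1 by 5-phenyl-2H-tetrazol-2-yl in place of 4-phenyl-1H-imidazol-1-yl on a saturated chain carbon, three bonds along the chain from an oxygen on an aromatic ring. Going by the values given here, no measured step touches this part of the structure, so the two large steps above give no direct guide to its size or direction; they only show that the urea side of compound 1, which compound 4 keeps intact, is what sets its low number. With the urea retained, a change beyond the scatter in this assay is possible but not indicated by any measured pair. Compound 4 is therefore expected to give 80 nM, in the range 20 nM to 400 nM. That estimate corresponds to a 2.6-fold higher number from compound 1 to compound 4 (0.41 log units; beyond the scatter), a modest expected weakening with wide uncertainty.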

Compound 4, half-maximal inhibitory concentration: 23 nM
For compound 4 the middle estimate is 3.5-fold (0.54 log units) above the measured one, and the stated range covers the measured number.
By their numbers in this assay, from the lowest: compounds 4 and 1 (each within the scatter of the next); then compound 3; then compound 2.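

In this assay, 5-phenyl-2H-tetrazol-2-yl in place of 4-phenyl-1H-imidazol-1-yl on a saturated chain carbon gives a 1.3-fold lower number from compound 1 to compound 4 (0.13 log units; within the scatter). Going by these compounds alone, this is the first reading at this position: with the urea kept, a five-membered aromatic ring with 4 hetero atoms stands in for one with 2 and the number stays within the scatter, in contrast to the large steps on the urea side. No measurement bears on why the two rings read alike.

Still open, going by these compounds, is whether the position accepts a less closely matched group, such as a carboxylic acid or an amine on the phenyl ring, or a longer chain leading to the five-membered ring. Also open, on these data alone, is whether methyl in place of hydrogen on the amide-type nitrogen costs as much with the tetrazole as it does with the imidazole.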